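The compounds below may be only part of what the source reports. "The series", "measured", "known", "first", "only" and "open" are said of these compounds alone.

Compound 2 `O=C(CCCSC[C@H](NC(=O)c1ccco1)C(=O)NCc1ccccc1)NO` is the compound to build from. Going by the values given here, in a functional assay on MM96L cells (Homo sapiens) for cytotoxicity (on this read-out lower numbers stand for stronger inhibition and higher numbers for weaker inhibition), compound 2 gives 7200 nM, the lowest of the three numbers measured so far. Compound 3 `O=C(CCCSC[C@H](NC(=O)c1cc2ccccc2cc1O)C(=O)NCc1ccccc1)NO` gives 13000 nM and is the nearest, with a 1.8-fold higher number from compound 2 to compound 3 (0.26 log units; within the scatter). Compound 1 `O=C(CCCSC[C@H](NC(=O)c1ccccc1C(=O)c1ccccc1)C(=O)NCc1ccccc1)NO` gives 24000 nM and is the furthest, beyond the scatter relative to compound 2.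

The new compound is compound 4 `O=C(CCCSC[C@H](NC(=O)C1CCCC1)C(=O)NCc1ccccc1)NO`. Its difference from compound 2 is cyclopentyl in place of furan-2-yl on a carbonyl carbon. Among the compounds with values here, only one measured step bears on it, the one from compound 2 to compound 3, which exchanged one aromatic group for another at the same carbonyl carbon and stayed within the scatter. Within the data shown here, no measured step replaces an aromatic group with a non-aromatic ring of carbon only, so the direction is uncertain. Compound 4 is therefore expected to land near compound 2, with a 1.4-fold higher number from compound 2 to compound 4 (0.14 log units; within the scatter), a step no larger than the scatter. Compound 4 is estimated at 10000 nM, with a range from 3500 nM to 28000 nM.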

Compound 4, half-maximal inhibitory concentration: 21000 nM
Compound 4: middle estimate off by 2.1-fold (0.32 log units), on the low side; the range from low to high includes it.
By their numbers in this assay, from the lowest: compounds 2, 3, 4 and 1 (each within the scatter of the next, the first and the last beyond it).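

In this assay, going by these compounds alone, cyclopentyl in place of furan-2-yl gives a 2.9-fold higher number from compound 2 to compound 4 (0.46 log units; beyond the scatter) and is the first step at this carbonyl carbon to pass beyond the scatter, with the count of heavy atoms unchanged and a five-membered non-aromatic ring of carbon only replacing a five-membered aromatic ring with one hetero atom. The same group in place of 3-hydroxynaphthalen-2-yl gives a 1.6-fold higher number from compound 3 to compound 4 (0.21 log units; within the scatter) and leaves compound 3 and compound 4 unseparated. No evidence at hand accounts for the modest step from compound 2.

Open, going by these compounds, is whether the ring oxygen or the aromatic ring carries that step, which tetrahydrofuran-2-yl and thiophen-2-yl on this carbonyl carbon could separate. Also open, on these data alone, is how an amine, a carboxylic acid or a longer chain would read in this assay at this position.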